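Aryl for Aryl at the Pyrazole Carbon: Furan Replaces Fluorophenyl

A few compounds are considered here, and "the series" means these few. Any claim that something is new, unique, unknown or untested is made for them only; others in the source may bear on it.

This account follows three measured compounds and one still untested. Compound 1 `CCCc1n[nH]c2c(=O)n(NC(=O)c3ccccc3)c(-c3cccc([N+](=O)[O-])c3)nc12` carries a propyl group on the shared core; in a functional assay on HT-29 cells (Homo sapiens) for cytotoxicity, read by sulforhodamine B assay, with a stated time of 2 days, tested at 100 uM (on this read-out higher numbers stand for more inhibition at the one concentration tested (going by the name of the read-out) and lower numbers for less inhibition), compound 1 gives 18.7%. Compound 2 `O=C(Nn1c(-c2cccc([N+](=O)[O-])c2)nc2c(-c3cccc(Cl)c3)n[nH]c2c1=O)c1ccccc1` bears a 3-chlorophenyl group in that place, and compound 2 reaches 89.8%. Compound 3 `O=C(Nn1c(-c2cccc([N+](=O)[O-])c2)nc2c(-c3ccc(F)cc3)n[nH]c2c1=O)c1ccccc1` carries a 4-fluorophenyl group there, and compound 3 gives 92%, the highest of the three numbers, though its gap to compound 2 lies within the scatter, while compound 1 lies far below it.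

The measured steps show one clear pattern: a number 73.3 percentage points higher from compound 1 to compound 3 (beyond the scatter) and a number 71.1 percentage points higher from compound 1 to compound 2 (beyond the scatter), whereas a number 2.2 percentage points higher from compound 2 to compound 3 (within the scatter) is within the scatter. Putting an aromatic ring in place of the propyl chain therefore moved the read-out strongly, and swapping one six-membered aromatic ring for another did not.

Compound 4 `O=C(Nn1c(-c2cccc([N+](=O)[O-])c2)nc2c(-c3ccco3)n[nH]c2c1=O)c1ccccc1` differs from compound 3 by the change (furan-2-yl in place of 4-fluorophenyl on an aromatic carbon). Because a number 2.2 percentage points higher from compound 2 to compound 3 (within the scatter) stayed within the scatter when one aromatic ring replaced another in that place and an aromatic ring again remains there, the step of a number 12 percentage points lower from compound 3 to compound 4 (beyond the scatter) is expected to be modest, with some allowance for the smaller five-membered ring. Compound 4 is estimated at 80%, with a range from 55% to 95%.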

Compound 4, a percentage reported as inhibition, at one concentration (the size of the read-out at that concentration, not a potency): 21.2%
Estimate against measurement, compound 4: 58.8 percentage points above; measured number below the stated range.
By their numbers in this assay, from the lowest: compounds 1 and 4 (each within the scatter of the next); then compounds 2 and 3 (each within the scatter of the next).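

The result shows that an aromatic ring on this carbon is not enough in itself to hold the read-out in this assay, since furan-2-yl gives a number 70.8 percentage points lower from compound 3 to compound 4 (beyond the scatter) and, against the other six-membered ring, a number 68.6 percentage points lower from compound 2 to compound 4 (beyond the scatter) in this comparison. The aromatic furan-2-yl ring also does not separate from the open chain, with a number 2.5 percentage points higher from compound 1 to compound 4 (within the scatter) and so no gain from the ring over propyl here. Among these four compounds the position therefore divides into a high pair carrying 4-fluorophenyl or 3-chlorophenyl and a low pair carrying propyl or furan-2-yl, so the earlier contrast of ring against chain does not hold, and compound 4 goes against it.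

Furan-2-yl differs from both phenyl groups at once in ring size, heavy atoms, hetero atom and hydrogen-bond acceptor, and nothing given here says which of these matters or explains the size of the change. Going by these compounds, whether a thiophene ring, with sulfur in place of the furan oxygen, or an unsubstituted phenyl group would join the high pair or the low pair remains open.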